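From Ethoxycarbonyl to 3-Hydroxycyclohexyl on the Aromatic Nitrogen

A few compounds are considered here, and "the series" means these few. Any claim that something is new, unique, unknown or untested is made for them only; others in the source may bear on it.

Two compounds sharing a common core have been examined in an assay for inhibition of Tryptophan 2,3-dioxygenase (Homo sapiens), with a stated time of 1 h, tested at 10 uM; a lower number here means less inhibition, a higher number more inhibition at the concentration tested (going by the name of the read-out). Compound 1 `FC(F)(F)c1cccc(CNc2cc(Br)cc3[nH]ncc23)c1` carries a trifluoromethyl group on its outer ring, and in this assay compound 1 gives 56%. Compound 2 `CCOC(=O)Nc1cccc(CNc2cc(Br)cc3[nH]ncc23)c1` instead bears an ethoxycarbonyl group on a nitrogen on an aromatic ring, and in this assay compound 2 is reported as "not active" (no number reported), with no number attached. Compound 2 therefore stands without a single figure; all that is known is that compound 2 is reported as not active, whereas compound 1 has a measured number for inhibition in this assay.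

Compound 3 `OC1CCCC(Nc2cccc(CNc3cc(Br)cc4[nH]ncc34)c2)C1` has not yet been tested. It differs from compound 2 in one place: 3-hydroxycyclohexyl in place of ethoxycarbonyl on a nitrogen on an aromatic ring. Within the data shown here, no measured pair in this set bridges such a change, so the size of the step cannot be drawn from the data. Given that compound 2 shows "not active" (no number reported), the account expects compound 3 to remain modest, while allowing room either way. The estimate for compound 3 in this assay is 20%, with a range from 0% to 50%.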

Compound 3, a percentage reported as inhibition, at one concentration (the size of the read-out at that concentration, not a potency): 50%
The estimate for compound 3 lay 30 percentage points below the measured number, and the stated range covers the measured number.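

In this assay compound 2 is reported as "not active" (no number reported), while compound 3, with 3-hydroxycyclohexyl in place of ethoxycarbonyl on the same nitrogen on an aromatic ring, gives 50%; the size of that change cannot be read, as compound 2 has no number, but the result shows that a substituted nitrogen at this place can go with measurable inhibition. Set against trifluoromethyl on the aromatic carbon, the (3-hydroxycyclohexyl)amino group gives a number 6 percentage points lower from compound 1 to compound 3 (within the scatter), so the two groups cannot be told apart in this assay. The data offer no measurement that explains the gap between ethoxycarbonyl and 3-hydroxycyclohexyl on this nitrogen.

Still open, as far as these compounds go, is whether the inhibition seen with compound 3 depends on the hydroxyl or on the carbon ring, a question that a plain cyclohexyl group, a free amine or a straight butyl chain on that nitrogen would help to settle. The compounds shown also leave open whether any group at this place can take inhibition clearly beyond that of compound 1 and compound 3.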